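The source may hold more compounds than are shown below. What is called first, only, known or untested is meant among the compounds shown, and "the series" means these compounds.

Measured so far in a functional assay on DU-145 cells (Homo sapiens) for inhibition; a lower number here means a stronger inhibitor, a higher number a weaker inhibitor:
compound 1 `Oc1ccc(-c2cc(-c3ccccc3F)cc(-c3cccc(O)c3)n2)cc1` gives 3160 nM;
compound 2 `Oc1ccc(-c2cc(-c3ccccc3C(F)(F)F)cc(-c3cccc(O)c3)n2)cc1` gives 2750 nM;
compound 3 `Oc1ccc(-c2cc(-c3cccc(C(F)(F)F)c3)cc(-c3cccc(O)c3)n2)cc1` gives 11100 nM.

Compound 3 carries the highest number of the three, and so is the weakest inhibitor here: a 3.5-fold higher number from compound 1 to compound 3 (0.55 log units; beyond the scatter) and a 4.0-fold higher number from compound 2 to compound 3 (0.61 log units; beyond the scatter). The next compound, compound 4 `Oc1ccc(-c2cc(-c3cccc(OC(F)(F)F)c3)cc(-c3cccc(O)c3)n2)cc1`, differs from compound 3 in one place: trifluoromethoxy in place of trifluoromethyl on an aromatic carbon. The measured step that resembles this most is one that also swapped one small group for another at an unchanged place on the same ring, and it changed little: a 1.1-fold lower number from compound 1 to compound 2 (0.06 log units; within the scatter). The two larger steps, from compound 1 and from compound 2 to compound 3, moved the group to another place on the ring and do not bear on a swap at a fixed place. On that basis no step beyond the scatter is expected for compound 4, in either direction: a 1.1-fold lower number from compound 3 to compound 4 (0.05 log units; within the scatter). Compound 4 is therefore estimated at 10000 nM, between 4000 nM and 25000 nM.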

Compound 4, half-maximal inhibitory concentration: 5670 nM
For compound 4 the middle estimate is 1.8-fold (0.25 log units) above the measured one; low and high end bracket the measured number.
By their numbers in this assay, from the lowest: compounds 2, 1, 4 and 3 (each within the scatter of the next, the first and the last beyond it).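

On a ring carbon meta to a large group, trifluoromethoxy in place of trifluoromethyl gives a 2.0-fold lower number from compound 3 to compound 4 (0.29 log units; within the scatter) in this assay, so this position tolerates the swap and the two groups cannot be told apart in this assay. The one hydrogen-bond acceptor that enters with trifluoromethoxy therefore brings no change beyond the scatter. Nothing available explains this result. From the compounds shown here alone, whether an amine, a carboxylic acid or a longer chain at this place would give a step beyond the scatter remains open.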